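The compounds below may be only part of what the source reports. "The series", "measured", "known", "first", "only" and "open" are said of these compounds alone.

Measured so far in a functional assay on A549 cells (Homo sapiens) for inhibition, read by CCK-8 assay, with a stated time of 48 h; a higher number here means a weaker inhibitor, a lower number a stronger inhibitor: compound 1 `COc1cc(-c2ccnc3cc(-c4ccc(Cl)cc4)nn23)cc(OC)c1OC` gives 3070 nM; compound 2 `COc1cc(-c2ccnc3cc(-c4ccc(F)cc4)nn23)cc(OC)c1OC` gives 3800 nM. Compound 3 `COc1cc(-c2ccnc3cc(-c4cccc(C#N)c4)nn23)cc(OC)c1OC` reaches only the limit of the assay, > 10000 nM, so no number is known for it (the limit of > 10000 nM in this assay, at which 1 of the 3 values shown sits).

Compound 3 therefore stands at the weak end of the three, with an at least 3.2-fold higher number from compound 1 to compound 3 (0.51 log units; beyond the scatter) and an at least 2.6-fold higher number from compound 2 to compound 3 (0.42 log units; beyond the scatter), while a 1.2-fold higher number from compound 1 to compound 2 (0.09 log units; within the scatter) stays within the scatter.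

Compound 4 `COc1cc(-c2ccnc3cc(-c4cccc(C)c4)nn23)cc(OC)c1OC` differs from compound 3 by methyl in place of cyano on an aromatic carbon. Within the data shown here, no measured step changes a cyano to a methyl, and none places a methyl on this ring, so the two steps above bear only indirectly: both show a 3-cyanophenyl sitting beyond the reach of the numbers. The estimate for compound 4 is 8000 nM, between 3000 nM and 25000 nM, which would mean an expected step of an at least 1.2-fold lower number from compound 3 to compound 4 (0.09 log units; that floor lies within the scatter).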

Compound 4, half-maximal inhibitory concentration: 5730 nM
Beside the measured number, compound 4's estimate is 1.4-fold (0.14 log units) above it; the measured number falls inside the stated range.
By their numbers in this assay, from the lowest: compounds 1, 2 and 4 (each within the scatter of the next). At a limit, above all of these: compound 3.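

Methyl in place of cyano brings this position back to a measurable number, with an at least 1.7-fold lower number from compound 3 to compound 4 (0.24 log units; that floor lies within the scatter), though the full size of that step stays unknown: the limit of > 10000 nM in this assay, at which 1 of the 4 values shown sits.

A substituent in this place does not by itself set a compound apart from the 4-halophenyl compounds, with a 1.9-fold higher number from compound 1 to compound 4 (0.27 log units; within the scatter) and a 1.5-fold higher number from compound 2 to compound 4 (0.18 log units; within the scatter). Among these compounds, the loss seen at the limit therefore goes with cyano and not with the place alone.

Going by these compounds, whether an amine, a hydroxyl or a carboxylic acid in this place would read like methyl or like cyano stays open.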